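The compounds below may be only part of what the source reports. "The series", "measured", "known", "first", "only" and "open" are said of these compounds alone.

Measured so far: compound 1, `CC(C)C/N=C(\S)NCCCCn1nc(-c2ccccc2)ccc1=O`; compound 2, `C/N=C(\NC#N)NCCCCn1nc(-c2ccccc2)ccc1=O`.

In a functional assay on the whole organism (stomach) with Rattus norvegicus as the target (a higher number here means that more compound is needed for the effect, a lower number that less compound is needed), compound 1 gives only a limit, > 100 mg/kg. In this assay compound 2 gives 32.4 mg/kg, the single real number shown; its standing rests on the limit of > 100 mg/kg in this assay, at which 1 of the 2 values shown sits, alone. The unmeasured compound 3 is `CC/N=C(\S)NCCCCCn1nc(-c2ccccc2)ccc1=O`. Relative to compound 2 it carries a group of 7 heavy atoms (4 carbon, 2 nitrogen, 1 sulfur; no ring) in place of a group of 7 heavy atoms (3 carbon, 4 nitrogen; no ring), on a saturated chain carbon, four bonds along the chain from an aromatic nitrogen. Among the measured compounds shown here, one measured step bears on this change: an at least 3.0-fold lower number from compound 1 to compound 2 (0.48 log units; beyond the scatter), a swap of much the same kind run in the opposite direction. The expectation is therefore a move toward a higher number, estimated as a 3.1-fold higher number from compound 2 to compound 3 (0.49 log units; beyond the scatter). Compound 3 is thus expected to give about 100 mg/kg, within roughly 40 mg/kg to 300 mg/kg.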

Compound 3, dose for half-maximal effect: 51.8 mg/kg
Compound 3: middle estimate off by 1.9-fold (0.29 log units), on the high side; the measured number falls inside the stated range.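

In this assay, the swap on the saturated chain carbon, four bonds along the chain from an aromatic nitrogen, gives a 1.6-fold higher number from compound 2 to compound 3 (0.20 log units; within the scatter), so the two groups cannot be told apart here. The other new step reads an at least 1.9-fold lower number from compound 1 to compound 3 (0.28 log units; that floor lies within the scatter), which establishes no real gain. The larger earlier step therefore did not carry over to this swap, and one end of that step is only a limit: the limit of > 100 mg/kg in this assay, at which 1 of the 3 values shown sits.

Still open, from the compounds shown here alone, is how a urea in place of these groups would read in this assay. Going by these compounds, a longer chain carrying the sulfur group is equally open.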